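Swapping phenyl for an amide chain

A few compounds are considered here, and "the series" means these few. Any claim that something is new, unique, unknown or untested is made for them only; others in the source may bear on it.

In a functional assay (ileum) for inhibition, with Cavia porcellus as the target (on this read-out lower numbers stand for stronger inhibition and higher numbers for weaker inhibition), compound 3 (`Cc1c(C)c2c(c(C)c1O)SC(c1ccccc1)O2`) gives 6600 nM and compound 1 (`CCCCC1Oc2c(C)c(C)c(O)c(C)c2S1`) gives 11900 nM, two values within the scatter of each other. Compound 2 (`CCCCCCCC1Oc2c(C)c(C)c(O)c(C)c2S1`) gives > 33900 nM, which is a limit of the assay. Compound 4 (`Cc1c(C)c2c(c(C)c1O)SC(CCC(N)=O)O2`) carries 2-carbamoylethyl in place of phenyl on a saturated ring carbon. Within the data shown here, two measured steps bear on this change. Exchanging butyl for phenyl gave a 1.8-fold lower number from compound 1 to compound 3 (0.26 log units; within the scatter), while adding propyl to the chain gave an at least 2.8-fold higher number from compound 1 to compound 2 (0.45 log units; beyond the scatter). Among the measured compounds shown here, no measured compound carries an amide, so only a modest move towards a higher number is expected. The expected step is a 2.1-fold higher number from compound 3 to compound 4 (0.33 log units; beyond the scatter). For compound 4 the estimate is 14000 nM, with an expected range of 5000 nM to 40000 nM.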

Compound 4, half-maximal inhibitory concentration: 3100 nM
Compound 4: middle estimate off by 4.5-fold (0.65 log units), on the high side; the whole stated range lies above it.
By their numbers in this assay, from the lowest: compound 4; then compounds 3 and 1 (each within the scatter of the next). At a limit, above all of these: compound 2.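

In this assay, a ring is not needed at this saturated ring carbon for the lowest number of the four: 2-carbamoylethyl gives a 2.1-fold lower number from compound 3 to compound 4 (0.33 log units; beyond the scatter), and against butyl the same kind of chain gives a 3.8-fold lower number from compound 1 to compound 4 (0.58 log units; beyond the scatter). Chain length alone therefore does not settle the result, since a carbamoyl end in place of pentyl gives an at least 10-fold lower number from compound 2 to compound 4 (1.03 log units; beyond the scatter). The value of compound 2 is a limit, so that step is only a bound: the limit of > 33900 nM in this assay, at which 1 of the 4 values shown sits.

From the compounds shown here alone, whether the amide itself matters remains open. A carboxylic acid, an amine or a nitrile at the chain end, or a longer chain carrying the carbamoyl, could separate the end group from chain length.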